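A few compounds are considered here, and "the series" means these few. Any claim that something is new, unique, unknown or untested is made for them only; others in the source may bear on it.

In an ADME assay on HepG2 cells (Homo sapiens) for cytotoxicity, in the presence of a further agent that is not named here (on this read-out higher numbers stand for weaker inhibition and lower numbers for stronger inhibition), three relatives have been tested so far. Compound 1 (`O=C(NCc1ccccc1)c1nc(Cc2ccccc2C(F)(F)F)[nH]c(=O)c1O`) gives > 100000 nM, which is a limit of the assay and not a number. Compound 2 (`Cn1c(Cc2ccccc2C(F)(F)F)nc(C(=O)NCc2cccnc2)c(O)c1=O`) gives > 100000 nM, also a limit. Compound 3 (`Cn1c(Cc2ccccc2C(F)(F)F)nc(C(=O)NCC2CCCCC2)c(O)c1=O`) gives > 100000 nM, again a limit. The whole picture therefore rests on (the limit of > 100000 nM in this assay, at which 3 of the 3 values shown sit). The next change leads from compound 3 to compound 4 (`Cn1c(Cc2ccccc2C(F)(F)F)nc(C(=O)NCc2ccccn2)c(O)c1=O`): pyridin-2-yl in place of cyclohexyl on a saturated chain carbon bound to an amide-type nitrogen. Going by the values given here, the one measured step that bears on it is a step that the two limits leave unreadable from compound 2 to compound 3, with cyclohexyl in place of pyridin-3-yl, and it offers no size to carry over. In this assay, the expected change is a step that the limit leaves unreadable from compound 3 to compound 4, so no shift beyond the scatter is expected. Compound 4 is estimated at 120000 nM, with an expected range of 60000 nM to 300000 nM.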

Compound 4, half-maximal inhibitory concentration: > 100000 nM
Compound 4: no number, only a limit; the forecaster's own chance of this, stated with the estimate: 88%; the middle value lies beyond the limit too.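

Compound 4 is again only a limit, so the steps to it from compound 2 and compound 3 cannot be read. The compounds shown leave open whether they differ at all, because all of them rest on one limit: the limit of > 100000 nM in this assay, at which 4 of the 4 values shown sit.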